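The source may report more compounds than this note shows. Statements on the series, on what has been measured and on what is new or still open speak of the compounds shown alone.

In a physicochemical assay for solubility, at pH 7.4 (a lower number here means a less soluble compound, a higher number a more soluble compound), compound 1 `CC(C)OC(=O)C1CN(C(=O)c2ccc(C#N)cc2)CC(C)(C)c2cc(C#N)[nH]c21` gives 21 ug/mL and compound 2 `CC(C)OC(=O)C1CN(C(=O)c2ccc(Cl)cc2)CC(C)(C)c2cc(C#N)[nH]c21` gives 5 ug/mL. Compound 3 `CC(C)OC(=O)C1CN(C(=O)c2cccc(F)c2)CC(C)(C)c2cc(C#N)[nH]c21` stands at > 100 ug/mL, which is a limit of the assay and not a number. Compound 4 `CC(C)OC(=O)C1CN(C(=O)C2CCOCC2)CC(C)(C)c2cc(C#N)[nH]c21` differs from compound 3 by one change, oxan-4-yl in place of 3-fluorophenyl on a carbonyl carbon.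

The closest measured steps are at that same place: an at least 4.7-fold higher number from compound 1 to compound 3 (0.67 log units; beyond the scatter), which is at least modest, and an at least 20-fold higher number from compound 2 to compound 3 (1.30 log units; beyond the scatter), which is large. Both exchange one substituted phenyl for another, and both end at the limit. The step of a 4.2-fold lower number from compound 1 to compound 2 (0.62 log units; beyond the scatter) is modest and shows that a change on the phenyl alone also registers in this assay. Among the measured compounds shown here, no measured step replaces the aromatic ring with a non-aromatic one, so the direction is uncertain and a real drop remains possible.

On balance, no step beyond the scatter is expected, and the expected step is an at least 1.2-fold lower number from compound 3 to compound 4 (0.09 log units; that floor lies within the scatter). For compound 4 the estimate is 80 ug/mL, with an expected range of 25 ug/mL to 160 ug/mL.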

Compound 4, solubility: > 100 ug/mL
Compound 4: no number, only a limit (the forecaster's own chance of this, stated with the estimate: 45%); middle value at least 1.2-fold (0.09 log units) away from the limit.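

In this assay compound 4 gives > 100 ug/mL, which is a limit of the assay and not a number. On this carbonyl carbon a non-aromatic ring, oxan-4-yl, also reaches that limit, with an at least 20-fold higher number from compound 2 to compound 4 (1.30 log units; beyond the scatter) and an at least 4.7-fold higher number from compound 1 to compound 4 (0.67 log units; beyond the scatter), so among the compounds shown an aromatic ring at this place is not needed for a reading at the limit. The step between compound 3 and compound 4 cannot be read, and the two compounds cannot be ordered: the limit of > 100 ug/mL in this assay, at which 2 of the 4 values shown sit.

On these data alone, what lies beyond the limit stays open, so oxan-4-yl and 3-fluorophenyl remain unranked. Also open, as far as these compounds go, is whether an amine such as piperidin-4-yl or a carboxylic acid on this carbonyl carbon would stay at the limit or fall towards the values of compound 1 and compound 2.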